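Methyl on the Ring Nitrogen, Moving From Compound 3 to Compound 4

The compounds below may be only part of what the source reports. "The series", "measured", "known", "first", "only" and "open" are said of these compounds alone.

Compound 2 `CN1CCN(c2nc(-c3cccc(O)c3)nc3[nH]cnc23)CC1` and compound 1 `CN1CCN(c2nc(-c3cccc(O)c3)nc3c2ncn3C)CC1` differ only by methyl in place of hydrogen on an aromatic nitrogen. In an assay on cells for displacement of a labelled ligand from adenosine receptor A2b (Homo sapiens), read by scintillation counting and radioligand binding, with a stated time of 30 min, tested at 10 uM (a lower number here means less inhibition, a higher number more inhibition at the concentration tested (going by the name of the read-out)), compound 2 gives 27%, while compound 1 gives 47.8%, so that a number 20.8 percentage points higher from compound 2 to compound 1 (beyond the scatter). Compound 3 `Clc1cccc(-c2nc(N3CCCCC3)c3nc[nH]c3n2)c1` rests on a different core; the difference between the two cores is not broken down here. In this assay compound 3 reaches only a limit of the assay, > 80%, and (the limit of > 80% in this assay, at which 1 of the 3 values shown sits). Compound 4 `Cn1cnc2c(N3CCCCC3)nc(-c3cccc(Cl)c3)nc21` differs from compound 3 by methyl in place of hydrogen on an aromatic nitrogen, the same change that was made from compound 2 to compound 1. Since compound 3 already sits at a limit, the step is expected to be a step that the limit leaves unreadable from compound 3 to compound 4, resting on the earlier step of a number 20.8 percentage points higher from compound 2 to compound 1 (beyond the scatter). Compound 4 is therefore expected to give about 87% in this assay, most likely between 70% and 97%.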

Compound 4, a percentage reported as inhibition, at one concentration (the size of the read-out at that concentration, not a potency): 24.2%
Compound 4: middle estimate off by 62.8 percentage points, on the high side, and the stated range ends above it.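

Compound 3 gives > 80% in this assay, which is a limit of the assay and not a number. Methyl in place of hydrogen on the aromatic nitrogen gave a number at least 55.8 percentage points lower from compound 3 to compound 4 (beyond the scatter), a step whose full size remains unknown. The change did not carry from one core to the other in direction or size, although the two steps do not show which difference between the cores sets them apart: the same change on two cores in this assay, a number 20.8 percentage points higher (beyond the scatter) from compound 2 to compound 1 and a number at least 55.8 percentage points lower (beyond the scatter) from compound 3 to compound 4, at least 76.6 percentage points apart, beyond the scatter of two such steps

From the compounds shown here alone, whether ethyl in place of methyl on that ring nitrogen would follow the same split on each core remains open. Also open, going by these compounds, is how the methyl step would read on any further core.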